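This account rests on a few compounds, and the source may have more. Where it says the series, first, only, none or still open, it means among the compounds named here.

Measured in a functional assay on HepG2 cells (Homo sapiens) for inhibition, read by MTT assay, with a stated time of 24 h; on this read-out lower numbers stand for stronger inhibition and higher numbers for weaker inhibition:
Compound 1 `Cc1ccc(C(=O)NCC(=O)N/N=C/c2ccccc2OCc2ccccc2Cl)cc1`: 13400 nM.
Compound 2 `Cc1ccc(C(=O)NCC(=O)N/N=C/c2ccccc2OCc2ccc(C#N)cc2)cc1`: > 50000 nM.

Compound 2 gives no number, only (the limit of > 50000 nM in this assay, at which 1 of the 2 values shown sits). Compound 3 `Cc1ccc(C(=O)NCC(=O)N/N=C/c2ccccc2OCc2ccc(Cl)cc2)cc1` has chloro in place of cyano on an aromatic carbon, para to a large group: chloro in place of cyano on an aromatic carbon. Among the measured compounds shown here, one measured step bears on this change: an at least 3.7-fold higher number from compound 1 to compound 2 (0.57 log units; beyond the scatter). That step put 4-cyanophenyl in place of 2-chlorophenyl, so removing the cyano group should move this assay towards a lower number, by a step of similar size. The expected change is an estimated at least 2.5-fold lower number from compound 2 to compound 3 (0.39 log units; beyond the scatter). Compound 3 is expected at 20000 nM, with an estimated range of 8000 nM to 50000 nM.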

Compound 3, half-maximal inhibitory concentration: > 50000 nM
Compound 3 ended at the assay's limit; the forecaster's own chance of this, stated with the estimate: 25%; middle value at least 2.5-fold (0.39 log units) from the limit.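

In this assay, 4-chlorophenyl in place of 2-chlorophenyl gives an at least 3.7-fold higher number from compound 1 to compound 3 (0.57 log units; beyond the scatter), so among these compounds the chloro group alone does not keep a readable number; where it sits on the ring matters. Compound 3 joins compound 2 at a limit of the assay, not a number: the limit of > 50000 nM in this assay, at which 2 of the 3 values shown sit. The step between compound 2 and compound 3 cannot be read, and neither can any difference between chloro and cyano at this place. Still open, from the compounds shown here alone, are how far both compounds lie past the limit and whether a methyl or a methoxy group in place of the chloro of compound 1 would keep a readable number.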